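A few compounds are considered here, and "the series" means these few. Any claim that something is new, unique, unknown or untested is made for them only; others in the source may bear on it.

Measured so far in a functional assay on the whole organism (strain Wistar) for inhibition, with Rattus norvegicus as the target, read by paw edema, with stated times of 30 min and 5 h, at a dose of 100 mg/kg by the oral route; on this read-out higher numbers stand for more inhibition at the one dose given (going by the name of the read-out) and lower numbers for less inhibition:

compound 1, `CCCCCCOc1cc(C(C)=O)ccc1N`, gives 14.1%
compound 2, `CCCCCCOc1cc(C(C)=O)ccc1NS(C)(=O)=O`, gives 76.8%
compound 3, `CC(=O)c1ccc(NS(C)(=O)=O)c(OC2CCCCC2)c1`, gives 73.7%

Compound 1 stands lowest of the three numbers. The step of a number 62.7 percentage points higher from compound 1 to compound 2 (beyond the scatter) shows how far a methylsulfonyl in place of hydrogen on the nitrogen lifts the inhibition, and compound 3 stands far above compound 1 as well. The step of a number 3.1 percentage points lower from compound 2 to compound 3 (within the scatter) is within the scatter, so the two alkoxy groups on the oxygen give no distinguishable difference on the methylsulfonyl-bearing core.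

Compound 4, `CCCCOc1cc(C(C)=O)ccc1N`, differs from compound 1 by hydrogen in place of ethyl on a saturated chain carbon, four bonds along the chain from an oxygen on an aromatic ring. Among the measured compounds shown here, no measured step shortens the chain on the oxygen, and the only change at that oxygen, from compound 2 to compound 3, was made on a compound carrying the methylsulfonyl, not on a free amine. For the measured compounds named here, the sole guide is therefore that exchanging the group on the oxygen left the inhibition unchanged there. For compound 4 a step of a number 2.1 percentage points lower from compound 1 to compound 4 (within the scatter) is expected, which is within the scatter. Compound 4 is estimated to give 12%, in the range from 0% to 30%.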

Compound 4, a percentage reported as inhibition, in the whole organism at one dose (the size of the read-out at that dose, not a potency): 13.8%
Compound 4: the middle estimate sits 1.8 percentage points below what was measured, within the range that was stated.
By their numbers in this assay, from the lowest: compounds 4 and 1 (each within the scatter of the next); then compounds 3 and 2 (each within the scatter of the next).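

In this assay, the exchange of hydrogen for ethyl on a saturated chain carbon, four bonds along the chain from an oxygen on an aromatic ring, gives a number 0.3 percentage points lower from compound 1 to compound 4 (within the scatter) and so leaves no distinguishable difference in inhibition. Among the compounds shown here, the one earlier change at this oxygen was made with the methylsulfonyl on the nitrogen, whereas this pair shows that, with a free amine on the same core, the butyl chain of compound 4 and the hexyl chain of compound 1 also cannot be told apart at this single oral dose. No measurement at hand speaks to why the chain length makes no visible difference in this pair.

Going by these compounds, whether the same shortening would also leave the number unchanged on the core of compound 2, with the methylsulfonyl on the nitrogen, remains open. So does what a shorter chain such as methyl or ethyl, a longer chain such as octyl, or a carboxylic acid in place of the butyl would give in this assay on either core.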